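The source may hold more compounds than are shown below. What is called first, only, known or untested is meant among the compounds shown, and "the series" means these compounds.

Measured compounds in an assay for inhibition of Fatty-acid amide hydrolase 1 (Rattus norvegicus); on this read-out lower numbers stand for stronger inhibition and higher numbers for weaker inhibition:
- compound 1, `O=C(O)c1ccc(-c2cnc(C(=O)CCc3ccc(-c4ccccc4)cc3)o2)cn1`, gives 44 nM
- compound 2, `COC(=O)c1ccc(-c2cnc(C(=O)CCc3ccc(-c4ccccc4)cc3)o2)nc1`, gives 2.2 nM
- compound 3, `CS(=O)(=O)c1cnc(C(=O)CCc2ccc(-c3ccccc3)cc2)o1`, gives 1.2 nM

Compound 1 stands at the highest number of the three, with compound 2 nearest and compound 3 furthest from it. Both steps away from compound 1 are large and beyond the scatter: a 20-fold lower number from compound 1 to compound 2 (1.30 log units; beyond the scatter) and a 37-fold lower number from compound 1 to compound 3 (1.56 log units; beyond the scatter). Between compound 2 and compound 3 the step is small: a 1.8-fold lower number from compound 2 to compound 3 (0.26 log units; within the scatter), within the scatter.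

The unmeasured compound 4, `COC(=O)c1cc(-c2cnc(C(=O)CCc3ccc(-c4ccccc4)cc3)o2)ccn1`, differs from compound 1 in a single place: 2-(methoxycarbonyl)pyridin-4-yl in place of 6-carboxypyridin-3-yl on an aromatic carbon. Among the compounds with values here, the step that bears most directly on this change is the one from compound 1 to compound 2, which also replaces the 6-carboxypyridin-3-yl bearing a hydrogen-bond donor with a methoxycarbonyl-substituted pyridyl carrying none, and that step was large. The step from compound 1 to compound 3 points the same way. Within the data shown here, no measured pair separates the position of the methoxycarbonyl group on the pyridine, so the size of that part of the change is unknown.

Compound 4 is therefore expected to give a lower number than compound 1, estimated as an 11-fold lower number from compound 1 to compound 4 (1.04 log units; beyond the scatter), landing near compound 2. The estimate for compound 4 is 4 nM, with a range from 1.3 nM to 15 nM.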

Compound 4, inhibition constant: 1.5 nM
Beside the measured number, compound 4's estimate is 2.7-fold (0.43 log units) above it, within the range that was stated.
By their numbers in this assay, from the lowest: compounds 3, 4 and 2 (each within the scatter of the next); then compound 1.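

In this assay, a 29-fold lower number from compound 1 to compound 4 (1.47 log units; beyond the scatter) is a second large step at this aromatic carbon next to the ring oxygen, while a 1.5-fold lower number from compound 2 to compound 4 (0.17 log units; within the scatter) stays within the scatter, so 2-(methoxycarbonyl)pyridin-4-yl and 5-(methoxycarbonyl)pyridin-2-yl cannot be told apart here, although the two pyridyl groups differ in how the ester and ring nitrogen are arranged. With a 1.3-fold higher number from compound 3 to compound 4 (0.10 log units; within the scatter) also within the scatter, methylsulfonyl joins these two ester-bearing groups in one tight cluster, and among the four compounds only compound 1, with its 6-carboxypyridin-3-yl, stands apart. No supporting measurement is available to explain either the large step or the cluster.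

The compounds shown leave open whether the gap to compound 1 follows the carboxylic acid itself or its particular pyridyl arrangement, as the acid appears on one arrangement only and neither ester shares that arrangement. Also open, as far as these compounds go, is how a primary amide, a hydroxymethyl group or a nitrile in place of the ester on the pyridine would read out in this assay on this same core.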